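Sulfonyl aryl swap in the shared core series

The compounds below may be only part of what the source reports. "The series", "measured", "known", "first", "only" and "open" are said of these compounds alone.

In a functional assay on HCT-116 cells (Homo sapiens) for inhibition, read by MTT assay, with a stated time of 72 h (a lower number here means a stronger inhibitor, a higher number a weaker inhibitor), compound 1 `CCOC(=O)c1oc2ccc(NS(=O)(=O)c3ccc(F)cc3)cc2c1C` gives > 40000 nM, which is a limit of the assay rather than a number. Compound 2 `CCOC(=O)c1oc2ccc(N(Cc3ccccc3)S(=O)(=O)c3ccccc3Br)cc2c1C` gives > 40000 nM in this assay, again only a limit. Going by the values given here, both known values therefore sit at the limit of > 40000 nM in this assay, at which 2 of the 2 values shown sit, so compound 2 stands nowhere distinct from compound 1, and no measured step exists. Compound 3 `CCOC(=O)c1oc2ccc(N(Cc3ccccc3)S(=O)(=O)c3ccc(Cl)cc3)cc2c1C` carries 4-chlorophenyl in place of 2-bromophenyl on a sulfonyl sulfur. With both known values at the limit, no step beyond the scatter is expected from compound 2 to compound 3, a number no higher from compound 2 to compound 3 (the limit leaves the size open). Compound 3 is expected at 40000 nM, in the range 15000 nM to 100000 nM, most likely reported once more as a limit.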

Compound 3, half-maximal inhibitory concentration: 23200 nM
Estimate against measurement, compound 3: 1.7-fold (0.24 log units) above, and the stated range covers the measured number.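

In this assay, the change at the sulfonyl sulfur gives an at least 1.7-fold lower number from compound 2 to compound 3 (0.23 log units; that floor lies within the scatter). Going by these compounds alone, compound 3 is the first compound to give a number rather than a limit, so with this group the read-out falls within the measurable range, although the true size of the step stays unknown. Most of the series still rests on a limit: the limit of > 40000 nM in this assay, at which 2 of the 3 values shown sit.

Because 4-chlorophenyl and 2-bromophenyl differ in both halogen and its placement, the compounds shown do not separate these two changes. On these data alone, how an amine or a carboxylic acid on this aryl ring would read also remains open.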